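Human microsome clearance: fluorophenyl swapped for tert-butoxymethyl

The source may hold more compounds than are shown below. What is called first, only, known or untested is meant among the compounds shown, and "the series" means these compounds.

Measured compounds:
compound 1 `O=C(NCc1cc(Cl)ccc1-n1cnnn1)[C@@H]1C[C@@H]2C[C@@H]2N1C(=O)[C@H](O)c1ccccc1F`: < 12 mL.min-1.g-1
compound 2 `CC(C)(C)OC[C@@H](O)C(=O)N1C[C@@H]2C[C@@H]2[C@H]1C(=O)NCc1cc(Cl)ccc1-n1cnnn1`: 37 mL.min-1.g-1

Two compounds of the series have been run in an ADME assay on liver for metabolic stability, with Liver microsome (Homo sapiens) as the target, read by LC-MS, using microsomes; on this read-out lower numbers stand for slow clearance and higher numbers for fast clearance. Compound 1 returns only a limit, < 12 mL.min-1.g-1, so its clearance is known just as a bound and not as a number (the limit of < 12 mL.min-1.g-1 in this assay, at which 1 of the 2 values shown sits). Compound 2 gives 37 mL.min-1.g-1 in this assay. Among the measured compounds shown here, no step between these two has been worked out, and their two values are all that can be said of the pair.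

The next compound, compound 3 `CC(C)(C)OC[C@@H](O)C(=O)N1[C@H](C(=O)NCc2cc(Cl)ccc2-n2cnnn2)C[C@@H]2C[C@@H]21`, has not yet been measured in this assay. It differs from compound 1 in one place: (tert-butoxy)methyl in place of 2-fluorophenyl on a saturated chain carbon bound to a carbonyl carbon and an oxygen on a saturated carbon. For the measured compounds named here, no measured step covers this change. Any expectation therefore rests on what compound 1 returns in this assay and on the number given by compound 2, 37 mL.min-1.g-1, which carries the entering group in a related setting.

The step of an at least 2.5-fold higher number from compound 1 to compound 3 (0.39 log units; beyond the scatter) is expected to run towards faster clearance, beyond the usual scatter. Compound 3 is estimated at 30 mL.min-1.g-1 in this assay, within 12 mL.min-1.g-1 to 70 mL.min-1.g-1.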

Compound 3, intrinsic clearance in microsomes: 21 mL.min-1.g-1
Compound 3: middle estimate off by 1.4-fold (0.15 log units), on the high side; the measured number falls inside the stated range.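

In this assay, (tert-butoxy)methyl in place of 2-fluorophenyl on a saturated chain carbon bound to a carbonyl carbon and an oxygen on a saturated carbon gives an at least 1.7-fold higher number from compound 1 to compound 3 (0.24 log units; that floor lies within the scatter). Among the compounds shown here, this is the first direct reading of the change on the core of compound 1, and it shows direction only as a floor, so a rise in clearance beyond the usual scatter is neither established nor excluded. The true size of the step remains unfixed, as the starting point for compound 3 is a limit of the assay and not a number: the limit of < 12 mL.min-1.g-1 in this assay, at which 1 of the 3 values shown sits.

Still open, from the compounds shown here alone, is where an amine, a carboxylic acid or a longer chain on this same carbon would fall in this assay, and so whether the reading belongs to the loss of the 2-fluorophenyl ring or to the entering (tert-butoxy)methyl itself. Also open, going by these compounds, is whether the same swap gives a step of similar size on a core other than that of compound 1.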